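Series notes: side-chain removal from compound 1

A few compounds are considered here, and "the series" means these few. Any claim that something is new, unique, unknown or untested is made for them only; others in the source may bear on it.

Compound 1, `N=C(N)NCCC[C@H](NC(=O)CN(c1ncnc2c1ncn2C1CCCCO1)C1CC1)C(=O)OCc1ccccc1`, is the reference point here. In a functional assay on the whole organism (Tail, strain ICR) with Mus musculus as the target, in the tail flick test, with a stated time of 120 min, at a dose of 25 umol/kg by the oral route (on this read-out lower numbers stand for a weaker effect and higher numbers for a stronger effect at the one dose given), compound 1 gives 38.2%, the highest of the three numbers measured; compound 2, `N=C(N)NCCC[C@H](NC(=O)CN(c1nc(Cl)nc2[nH]cnc12)C1CC1)C(=O)OCc1ccccc1`, gives 10.2% and compound 3, `NCCCC[C@H](NC(=O)CN(c1nc(Cl)nc2[nH]cnc12)C1CC1)C(=O)OCc1ccccc1`, gives 16.8%, both beyond the scatter below compound 1. Compound 4, `O=C(CN(c1ncnc2c1ncn2C1CCCCO1)C1CC1)NCC(=O)OCc1ccccc1`, differs from compound 1 in one place: a hydrogen atom in place of a group of 7 heavy atoms (4 carbon, 3 nitrogen; no ring), on a saturated chain carbon bound to an amide-type nitrogen and a carbonyl carbon. Among the compounds with values here, the only measured step that touches this part of the molecule is a number 6.6 percentage points higher from compound 2 to compound 3 (within the scatter), a change of the end group on the same chain within the other core; it did not move the read-out beyond the scatter. Within the data shown here, no measured pair shows the whole chain taken away, so the step to compound 4 goes further than any step measured so far, and a decrease in this assay is expected, of uncertain size. For compound 4 the estimate is 20%, with a range from 5% to 38%. The expected step is a number 18.2 percentage points lower from compound 1 to compound 4 (beyond the scatter).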

Compound 4, a percentage reported as activity, at one dose (the size of the read-out at that dose, not a potency): 17.2%
Compound 4: the middle estimate sits 2.8 percentage points above what was measured; measured number inside the range.
By their numbers in this assay, from the lowest: compounds 2, 3 and 4 (each within the scatter of the next); then compound 1.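

Putting a hydrogen atom in place of the group of 7 heavy atoms on this saturated chain carbon gives a number 21 percentage points lower from compound 1 to compound 4 (beyond the scatter) in this assay. This shows that the whole chain counts for the read-out at this position within the core of compound 1, which the end-group change, a number 6.6 percentage points higher from compound 2 to compound 3 (within the scatter), in the other core could not show. No available data bear on why the read-out falls when the chain is removed.

As far as these compounds go, it remains open how much of the chain is needed for the higher read-out. A methyl group on the same carbon, or a shorter chain ending in a carboxylic acid, on the core of compound 1 would help separate the presence of a substituent from the length and end group of the chain.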